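This account rests on a few compounds, and the source may have more. Where it says the series, first, only, none or still open, it means among the compounds named here.

For the measured compounds named here, in a functional assay on HeLa cells (Homo sapiens) for antiproliferative activity, read by MTT assay, with a stated time of 48 h (on this read-out lower numbers stand for stronger inhibition and higher numbers for weaker inhibition), compound 1 `COc1ccc(N(C)c2ccnc(Cl)n2)cc1Cl` gives 517 nM and compound 2 `COc1ccc(N(C)c2ccnc(Cl)n2)cc1O` gives 96 nM, so compound 2 holds the lower of only two numbers. Compound 3 `COc1ccc(N(C)c2ccnc(Cl)n2)cc1OCC[Se]C#N` differs from compound 2 by a group of 5 heavy atoms (3 carbon, 1 nitrogen, 1 selenium; no ring) in place of a hydrogen atom, on an oxygen on an aromatic ring, a group without a ring placed on an oxygen on an aromatic ring. Going by the values given here, one measured step bears on this change: hydroxy in place of chloro gave a 5.4-fold lower number from compound 1 to compound 2 (0.73 log units; beyond the scatter), a modest step beyond the scatter. Among the compounds with values here, no measured compound carries any group on that oxygen, so this step is only a loose guide. Within the data shown here, a step of similar modest size or smaller is expected, towards a higher number, since compound 3 no longer has the hydroxy of compound 2, and the one compound without it, compound 1, stands at 517 nM. The expected change is a 1.6-fold higher number from compound 2 to compound 3 (0.19 log units; within the scatter). In this assay the estimate for compound 3 is 150 nM, with an expected range of 35 nM to 650 nM.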

Compound 3, half-maximal inhibitory concentration: 436 nM
The estimate for compound 3 lay 2.9-fold (0.46 log units) below the measured number; measured number inside the range.
By their numbers in this assay, from the lowest: compound 2; then compounds 3 and 1 (each within the scatter of the next).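

In this assay, a group on the oxygen of the aromatic ring does not keep the number of the free hydroxy: the step is a 4.5-fold higher number from compound 2 to compound 3 (0.66 log units; beyond the scatter), so this oxygen does not tolerate every substituent without loss. Set against the chlorine, the whole chain-bearing ether gives a 1.2-fold lower number from compound 1 to compound 3 (0.07 log units; within the scatter), which places compound 3 and compound 1 within the scatter of each other and leaves compound 2 alone at the low end of the three. Nothing measured here accounts for the loss at this position.

From the compounds shown here alone, whether the loss follows from the selenium, from the nitrile or from any group at all on that oxygen remains open. A simple methyl ether, a chain ending in an amine or a carboxylic acid, or a longer chain on the same oxygen would separate these readings.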